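Butyl to but-1-en-1-yl: compound 2 to compound 4

A few compounds are considered here, and "the series" means these few. Any claim that something is new, unique, unknown or untested is made for them only; others in the source may bear on it.

Measured compounds:
Compound 1, `CCCCC(C)Cc1cc(CC)c(CC(=O)O)o1`: compound 1 gives > 100000 nM in a functional assay on K562 cells (Homo sapiens) for cytotoxicity, read by MTT assay, with a stated time of 72 h (on this read-out higher numbers stand for weaker inhibition and lower numbers for stronger inhibition), a limit of the assay.
Compound 2, `CCCC[C@H](CC)C[C@]1(CC)C=C(CC)/C(=C/C(=O)OC)O1`: compound 2 gives 5300 nM in this assay.
Compound 3, `CCC[C@@H]1[C@@H](C)C[C@](O)(CC)[C@H]1[C@]1(CC)OC(=O)C[C@@H]1O`: compound 3 gives > 100000 nM in this assay, a limit of the assay.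

For the measured compounds named here, compound 2 is the only member of the set with a numerical value in this assay; the other two sit at the limit of > 100000 nM in this assay, at which 2 of the 3 values shown sit, so no measured step between two numbers exists and no ordering of compound 2 against compound 1 or compound 3 can be stated beyond their not reaching a number.

The next compound, compound 4, is `CC/C=C/[C@H](CC)C[C@]1(CC)C=C(CC)/C(=C/C(=O)OC)O1`, and it is to be measured in this assay. It differs from compound 2 by but-1-en-1-yl in place of butyl on a saturated chain carbon bound to two saturated chain carbons. The shared core of compound 2 is kept; only the chain is altered, in size unchanged by heavy-atom count.

Going by the values given here, with a single numerical anchor and no measured step on this change, the expected step from compound 2 to compound 4 is none beyond the usual scatter, with no direction favoured. Compound 4 is therefore expected to give about 5000 nM in this assay, estimated between 1500 nM and 17000 nM. The estimate implies a step of a 1.1-fold lower number from compound 2 to compound 4 (0.03 log units; within the scatter), which is expected to stay within scatter.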

Compound 4, half-maximal inhibitory concentration: 800 nM
Compound 4: the middle estimate sits 6.3-fold (0.80 log units) above what was measured; measured number below the stated range.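

In this assay, the series gains its first measured step: a 6.6-fold lower number from compound 2 to compound 4 (0.82 log units; beyond the scatter). The chain position on a saturated chain carbon bound to two saturated chain carbons therefore responds to the double bond of but-1-en-1-yl, even though butyl and but-1-en-1-yl have the same heavy-atom count and neither carries a hydrogen-bond donor or acceptor. Nothing measured in this set accounts for the step, so it stands as an observation on this one pair.

The compounds shown leave open whether the double bond's geometry or its place in the chain matters, as the cis isomer and the but-2-en-1-yl and but-3-en-1-yl groups do not appear among them. Also open, going by these compounds, is how a longer chain such as hexyl, or a polar end group such as an amine or a carboxylic acid, would behave at this position.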